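Solubility notes on the series: compound 2 to compound 3

The source may report more compounds than this note shows. Statements on the series, on what has been measured and on what is new or still open speak of the compounds shown alone.

Compound 1 `FC(F)(F)c1cccc(-c2nc3cnc(Nc4ccncn4)cc3[nH]2)c1` and compound 2 `FC(F)(F)c1cccc(-c2nc3cnc(Nc4cccnn4)cc3[nH]2)c1` share one core and differ only in the group on the aromatic amine nitrogen. In a physicochemical assay for solubility, using the shake flask method, in phosphate buffer, measured as kinetic solubility, with a stated time of 20 h, at pH 6.5 (a lower number here means a less soluble compound, a higher number a more soluble compound), compound 1 gives < 5000 nM, which is a limit of the assay and not a number. In this assay compound 2 likewise gives < 5000 nM, again a limit rather than a measured value. The step that the two limits leave unreadable from compound 1 to compound 2 cannot be read because of the limit of < 5000 nM in this assay, at which 2 of the 2 values shown sit. Compound 2 thus stands at the limit, with nothing measured in the series to set it against. Compound 3 `N#Cc1ccc(Nc2cc3[nH]c(-c4cccc(C(F)(F)F)c4)nc3cn2)nc1` carries the change (5-cyanopyridin-2-yl in place of pyridazin-3-yl on a nitrogen on an aromatic ring). Among the compounds with values here, the only measured step is unreadable, so no size or direction follows from it for this change. For compound 3 the expectation in this assay is a value again near the limit, estimated at 2000 nM with a range from 500 nM to 5000 nM. The estimated step that the limit leaves unreadable from compound 2 to compound 3 is expected to stay within the scatter.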

Compound 3, solubility: < 5000 nM
Compound 3: a limit, no number (the forecaster's own chance of this, stated with the estimate: 70%); the middle value lies beyond the limit too.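

No new step can be read in this assay from compound 3 to compound 1 or compound 2, as all three sit at one limit: the limit of < 5000 nM in this assay, at which 3 of the 3 values shown sit.

The compounds shown leave open where compound 1, compound 2 and compound 3 actually stand in this assay, and whether the groups on the nitrogen differ at all.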